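Shortening the Amino Chain on a Weakly Binding Triazolopyrimidine Series

The source may hold more compounds than are shown below. What is called first, only, known or untested is meant among the compounds shown, and "the series" means these compounds.

Compound 1 `CCNc1nc(-c2ccccc2)nc2c1nnn2Cc1ccccc1Cl`: 463000000 nM
Compound 2 `CCCCNc1nc(-c2ccccc2)nc2c1nnn2Cc1ccccc1`: 11000000 nM
Compound 3 `CCCCNc1nc(-c2ccccc2)nc2c1nnn2Cc1ccccc1C(F)(F)F`: 6500000 nM

In an assay on isolated protein for binding affinity to adenosine receptor A1 (Bos taurus) (on this read-out lower numbers stand for stronger inhibition and higher numbers for weaker inhibition), compound 2 gives 11000000 nM, the second highest of the three numbers. Its nearest neighbour is compound 3, reached by a 1.7-fold lower number from compound 2 to compound 3 (0.23 log units; within the scatter); the furthest is compound 1, which gives 463000000 nM. The step to compound 4 `CCNc1nc(-c2ccccc2)nc2c1nnn2Cc1ccccc1` is hydrogen in place of ethyl on a saturated chain carbon, two bonds along the chain from a nitrogen on an aromatic ring. Among the measured compounds shown here, no measured step changes this chain, so nothing speaks directly to it. For the measured compounds named here, the only measured step, from compound 2 to compound 3, touches the aromatic ring and stays within the scatter. Compound 1 carries the same ethylamino chain as compound 4 together with a chlorine on the aromatic ring, and its value in this assay lies far above that of compound 2; since the one ring substitution that was measured changed little, much of that gap is plausibly attributable to the chain because compound 1 gives 463000000 nM while compound 2 gives 11000000 nM. The step from compound 2 to compound 4 is therefore expected to be a 9.1-fold higher number from compound 2 to compound 4 (0.96 log units; beyond the scatter), toward weaker binding. Compound 4 is estimated at 100000000 nM, with a range from 20000000 nM to 500000000 nM.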

Compound 4, inhibition constant: 91000000 nM
Compound 4: the middle estimate sits 1.1-fold (0.04 log units) above what was measured; measured number inside the range.
By their numbers in this assay, from the lowest: compounds 3 and 2 (each within the scatter of the next); then compound 4; then compound 1.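

In this assay, the change from butylamino to ethylamino now has a direct reading, an 8.3-fold higher number from compound 2 to compound 4 (0.92 log units; beyond the scatter), so on the shared core the shorter chain goes with weaker binding. Compound 4 also isolates the ring substituent, giving a 5.1-fold lower number from compound 1 to compound 4 (0.71 log units; beyond the scatter), which shows that this aromatic carbon can matter in the ethylamino series, whereas the trifluoromethyl step in the butylamino series gave a 1.7-fold lower number from compound 2 to compound 3 (0.23 log units; within the scatter). Nothing available explains either of the new steps.

The compounds shown leave open where a propylamino chain, or a longer one such as hexylamino, would fall relative to these values. They also leave open whether a chlorine on the aromatic ring would shift the number in the same way when paired with the butylamino chain.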